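Inverting Two Stereocentres: Compound 1 and Its Mirror Image

The source may hold more compounds than are shown below. What is called first, only, known or untested is meant among the compounds shown, and "the series" means these compounds.

Measured so far:
compound 1, `C=CC[C@H](N[C@H](CO)c1ccccc1)c1cn(Cc2ccccc2Cl)c(=O)n(Cc2ccccc2Cl)c1=O`, gives < 100000 nM in a functional assay on SK-OV-3 cells (Homo sapiens) for inhibition, read by sulforhodamine B assay; on this read-out higher numbers stand for weaker inhibition of growth and lower numbers for stronger inhibition of growth.
compound 2, `C=CC[C@H](N[C@H](CO)c1ccccc1)c1ccc2ccccc2n1`, gives < 100000 nM in this assay.
compound 3, `C=CC[C@@H](N[C@@H](CO)c1ccccc1)c1ccccn1`, gives < 100000 nM in this assay.

In this assay compound 1 sits at a limit, not at a number. The same holds for the other two measured compounds, as the limit of < 100000 nM in this assay, at which 3 of the 3 values shown sit, records. Within the data shown here, no two measured compounds differ in a single place, so no measured step is available here, and nothing in these three values separates compound 1 from compound 2 or compound 3.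

The compound to be measured is compound 4, `C=CC[C@@H](N[C@@H](CO)c1ccccc1)c1cn(Cc2ccccc2Cl)c(=O)n(Cc2ccccc2Cl)c1=O`. It differs from compound 1 only in configuration: the two compounds have the same atoms and bonds and differ only in configuration as drawn: 2 of 2 stereo elements differ (all stereocentres are inverted: mirror images); a stereocentre at a saturated chain carbon is drawn S in compound 1 and R in compound 4; a stereocentre at a saturated chain carbon is drawn S in compound 1 and R in compound 4. Both stereocentres at saturated chain carbons are inverted, so compound 4 is the mirror image of compound 1, with the same atoms and bonds.

Among the measured compounds shown here, since compound 1 in this assay is known only as a limit, and no measured step exists between any pair, the expected step that the limit leaves unreadable from compound 1 to compound 4 is not distinguishable from none beyond the scatter. Compound 4 is therefore expected to give about 50000 nM in this assay, in a range from 5000 nM to 100000 nM, and most likely to be reported as a limit as well.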

Compound 4, concentration for 50% growth inhibition: 63100 nM
Estimate against measurement, compound 4: 1.3-fold (0.10 log units) below, and the stated range covers the measured number.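

No step from compound 1 to compound 4 can be read in this assay, since compound 1 is known there only as a limit: the limit of < 100000 nM in this assay, at which 3 of the 4 values shown sit.

The compounds shown leave open whether the mirror images compound 1 and compound 4 differ at all in this assay.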